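Ortho substituent swap on the imidazoline ether series

The source may hold more compounds than are shown below. What is called first, only, known or untested is meant among the compounds shown, and "the series" means these compounds.

Measured so far:
compound 1, `CC(Oc1ccccc1Br)C1=NCCN1`: 0.87
compound 2, `COc1ccccc1OC(C)C1=NCCN1`: 0.6
compound 3, `CCc1ccccc1OC(C)C1=NCCN1`: 0.6

In an assay on CHO cells with Alpha-2C adrenergic receptor (Homo sapiens) as the target (a higher number here means a larger maximal response, a lower number a smaller maximal response), compound 3 stands level with compound 2 at the digits shown, the two together the lowest of the three numbers, while compound 1 sits higher: a number 0.27 lower from compound 1 to compound 3 (beyond the scatter), and no change at the digits printed from compound 2 to compound 3 (within the scatter). The next compound is compound 4, `CC(Oc1ccccc1C=O)C1=NCCN1`, which differs from compound 3 by formyl in place of ethyl on an aromatic carbon. Among the compounds with values here, no measured step exchanges an alkyl for a formyl group, so the two steps above are only a loose guide. The swap between methoxy and ethyl left the number unchanged, whereas bromo gave a modestly higher value. Compound 4 is therefore expected to stay near compound 3, with the step a number 0.050 higher from compound 3 to compound 4 (within the scatter), giving an estimated 0.65 in the range 0.45 to 0.85.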

Compound 4, intrinsic activity: the largest response reached, as a fraction of the reference agonist's: 0.6
Compound 4: the middle estimate sits 0.050 above what was measured, and the stated range covers the measured number.
By their numbers in this assay, from the lowest: compounds 2, 3 and 4 (each within the scatter of the next); then compound 1.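

In this assay the step of no change at the digits printed from compound 3 to compound 4 (within the scatter) shows that exchanging ethyl, with no hydrogen-bond acceptor, for formyl, with one, leaves the number in place at this aromatic carbon, and the step of no change at the digits printed from compound 2 to compound 4 (within the scatter) adds formyl to the level shared by methoxy and ethyl. Bromo remains the only group apart, with the step a number 0.27 lower from compound 1 to compound 4 (beyond the scatter) now seen against three different replacements. Nothing at hand accounts for this result.

Open, from the compounds shown here alone, is whether chloro or fluoro would share the higher number of bromo. Also open, going by these compounds, is whether an amine or a carboxylic acid at this carbon would leave the level of methoxy, ethyl and formyl.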